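The compounds below may be only part of what the source reports. "The series", "measured", "known", "first", "only" and "open" are said of these compounds alone.

Of the compounds shown here, two have so far been tested in a functional assay on SW480 cells (Homo sapiens) for cytotoxicity, read by MTT assay, with a stated time of 24 h; a lower number here means a stronger inhibitor, a higher number a weaker inhibitor. Compound 1 `C=CC1=C(C(=O)NCCCCC)C(c2ccc(Cl)c(Cl)c2)OC1` gives 27500 nM, and compound 2 `C=CC1=C(C(=O)NCc2ccc(OC)c(OC)c2)C(c2ccc(OC)cc2)OC1` gives 13500 nM. Compound 2 thus holds the lower of the two numbers, and compound 1 stands a step higher that lies beyond the scatter. Compound 3 `C=CC1=C(C(=O)NCc2ccc(OC)c(OC)c2)C(c2ccc(F)cc2)OC1` differs from compound 2 by fluoro in place of methoxy on an aromatic carbon. For the measured compounds named here, no pair of measured compounds isolates this exchange, so the expectation rests on the change alone. The number is expected to stay close to that of compound 2, with a step estimated as a 1.2-fold higher number from compound 2 to compound 3 (0.07 log units; within the scatter), not clearly beyond the scatter. Compound 3 is therefore expected to give 16000 nM, within a range from 7000 nM to 36000 nM.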

Compound 3, half-maximal inhibitory concentration: > 100000 nM
Compound 3: no number, only a limit; the forecaster's own chance of this, stated with the estimate: 5%; middle value at least 6.2-fold (0.79 log units) from the limit.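

In this assay, for the compounds shown here, the exchange of 4-methoxyphenyl for 4-fluorophenyl is the first single change that can be read, and it is not a silent one: an at least 7.4-fold higher number from compound 2 to compound 3 (0.86 log units; beyond the scatter). Compound 3 gives > 100000 nM, which is a limit of the assay and not a number: the limit of > 100000 nM in this assay, at which 1 of the 3 values shown sits. The position para to a large group therefore does not tolerate every small group equally, at least as far as methoxy and fluoro go.

Going by these compounds, this rests on one pair, so the true size of the step stays open. On these data alone, it also stays open whether a hydroxyl or an ethoxy at this place would behave like methoxy or like fluoro.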